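This account rests on a few compounds, and the source may have more. Where it says the series, first, only, none or still open, it means among the compounds named here.

In a physicochemical assay for solubility, in phosphate buffer, at pH 7.4 (a higher number here means a more soluble compound, a lower number a less soluble compound), compound 1 (`COCCOCCOCCOCCOCCOCCOCCOCCOCCOCCOC(=O)Oc1c(C(C)C)cccc1C(C)C`) reads > 314000 ug/mL, which is a limit of the assay and not a number. Compound 3 (`COCCOCCOCCOCCOCCOCCOCCOC(=O)Oc1c(C(C)C)cccc1C(C)C`) gives 2730 ug/mL, the higher of the two actual numbers, and compound 2 (`COCCOCCOCCOCC(=O)Oc1c(C(C)C)cccc1C(C)C`) gives 990 ug/mL. Compound 4 (`COCCOCCOCCOC(=O)Oc1c(C(C)C)cccc1C(C)C`) differs from compound 3 by a hydrogen atom in place of a group of 12 heavy atoms (8 carbon, 4 oxygen; no ring), on a saturated chain carbon bound to an oxygen on a saturated carbon. Within the data shown here, the one measured step of this kind, an at least 110-fold lower number from compound 1 to compound 3 (2.06 log units; beyond the scatter), also shortens the chain at this place, and it is large and beyond the scatter. As far as these compounds go, its true size is unknown, since it starts from a limit. A fall in this assay is therefore expected, though a much smaller one, estimated as a 3.4-fold lower number from compound 3 to compound 4 (0.53 log units; beyond the scatter). For compound 4 the expected value is 800 ug/mL, with an estimated range of 200 ug/mL to 3000 ug/mL.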

Compound 4, solubility: 190 ug/mL
For compound 4 the middle estimate is 4.2-fold (0.62 log units) above the measured one, outside the stated range (below it).
By their numbers in this assay, from the lowest: compound 4; then compound 2; then compound 3. At a limit, above all of these: compound 1.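

In this assay the loss of this group of 12 heavy atoms brings a 14-fold lower number from compound 3 to compound 4 (1.16 log units; beyond the scatter) and so gives this change its first measured size at this place, between two actual numbers. The earlier step of this kind has no known size, since compound 1 stands at a limit and not at a number: the limit of > 314000 ug/mL in this assay, at which 1 of the 4 values shown sits. The compounds shown leave open whether a still shorter chain would lower the number further. They also leave open how an amine or a carboxylic acid on the chain would read in this assay here.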